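Amino in place of (trifluoromethyl)sulfanyl: notes on compound 3

This account rests on a few compounds, and the source may have more. Where it says the series, first, only, none or still open, it means among the compounds named here.

Among the compounds with values here, in a physicochemical assay for solubility, at pH 7.4 (a lower number here means a less soluble compound, a higher number a more soluble compound), compound 2 `Cc1cc(NC(=O)Nc2ccc(SC(F)(F)F)cc2)c2ccccc2n1` gives 200 nM and stands lowest of the two numbers so far, under compound 1 `CC(=O)c1ccc(NC(=O)Nc2cc(C)nc3ccccc23)cc1` at 3800 nM on the shared core. Compound 3 `Cc1cc(NC(=O)Nc2ccc(N)cc2)c2ccccc2n1` has amino in place of (trifluoromethyl)sulfanyl on an aromatic carbon. Within the data shown here, the one measured step bearing on this is large: a 19-fold lower number from compound 1 to compound 2 (1.28 log units; beyond the scatter), with (trifluoromethyl)sulfanyl entering in place of acetyl. Its departure is therefore expected to give a large step upward in this assay, an expected 20-fold higher number from compound 2 to compound 3 (1.30 log units; beyond the scatter). For compound 3 the estimate is 4000 nM, with an expected range from 800 nM to 20000 nM.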

Compound 3, solubility: 18500 nM
Compound 3: the middle estimate sits 4.6-fold (0.67 log units) below what was measured; measured number inside the range.
By their numbers in this assay, from the lowest: compound 2; then compound 1; then compound 3.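

In this assay, amino at this position gives a 93-fold higher number from compound 2 to compound 3 (1.97 log units; beyond the scatter), and it also separates clearly from acetyl, with a 4.9-fold higher number from compound 1 to compound 3 (0.69 log units; beyond the scatter). Among the three groups on this aromatic carbon, amino therefore gives the highest number and (trifluoromethyl)sulfanyl the lowest, with every step beyond the scatter. Nothing available explains this order.

As far as these compounds go, whether a hydroxyl, a dimethylamino group or a carboxylic acid at this position would fall within the same span remains open. So does whether amino in place of acetyl gives a similar step on another core.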